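Swapping a bromo-hydroxyphenyl for a nitrooxyphenyl

A few compounds are considered here, and "the series" means these few. Any claim that something is new, unique, unknown or untested is made for them only; others in the source may bear on it.

Compound 3 `CN(C)CCn1cnnc1-c1cc(Oc2ccc(NC(=O)N/N=C/c3ccc(O)c(Br)c3)cc2F)ccn1` gives 1370 nM in a functional assay on A549 cells (Homo sapiens) for cytotoxicity, read by MTT assay, with a stated time of 72 h (on this read-out lower numbers stand for stronger inhibition and higher numbers for weaker inhibition), the highest of the two numbers, with compound 1 `CN(C)CCn1cnnc1-c1cc(Oc2ccc(NC(=O)N/N=C/c3cccc(Br)c3)cc2F)ccn1` nearest at 970 nM. Compound 2 `CN(C)CCn1cnnc1-c1cc(Oc2ccc(NC(=O)N/N=C/c3cccc(O)c3)cc2F)ccn1` reaches only the assay limit of > 100000 nM. Compound 4 `CN(C)CCn1cnnc1-c1cc(Oc2ccc(NC(=O)N/N=C/c3ccccc3O[N+](=O)[O-])cc2F)ccn1` is not yet measured; its change from compound 3 is 2-(nitrooxy)phenyl in place of 3-bromo-4-hydroxyphenyl on a carbon with a double bond to nitrogen. The bearing steps were large: an at least 100-fold higher number from compound 1 to compound 2 (2.01 log units; beyond the scatter) and an at least 72-fold lower number from compound 2 to compound 3 (1.86 log units; beyond the scatter), while a 1.4-fold higher number from compound 1 to compound 3 (0.15 log units; within the scatter) was small. On these data alone, because the limit of > 100000 nM in this assay, at which 1 of the 3 values shown sits, shows that removing the bromo with a hydroxy present wipes out activity, and compound 4 also lacks bromo, a step of a 4.4-fold higher number from compound 3 to compound 4 (0.64 log units; beyond the scatter) towards weaker inhibition is expected, though the nitrooxy group is untested here. Compound 4 is therefore estimated at 6000 nM, between 900 nM and 60000 nM.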

Compound 4, half-maximal inhibitory concentration: 1200 nM
Compound 4: the middle estimate sits 5.0-fold (0.70 log units) above what was measured; measured number inside the range.
By their numbers in this assay, from the lowest: compounds 1, 4 and 3 (each within the scatter of the next). At a limit, above all of these: compound 2.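

In this assay, this position turns out not to need bromine for activity: the result is a 1.1-fold lower number from compound 3 to compound 4 (0.06 log units; within the scatter) and a 1.2-fold higher number from compound 1 to compound 4 (0.09 log units; within the scatter), so the 2-(nitrooxy)phenyl ring, with no bromine and no hydrogen-bond donors, cannot be told apart from either bromo ring. The other comparison gives an at least 83-fold lower number from compound 2 to compound 4 (1.92 log units; beyond the scatter), so the loss seen with 3-hydroxyphenyl does not extend to every ring without bromine. Compound 2 remains a limit of the assay: the limit of > 100000 nM in this assay, at which 1 of the 4 values shown sits.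

On these data alone, it remains open whether the nitrooxy group itself matters, and a plain phenyl ring or a 2-nitrophenyl ring would test that.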